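The source may hold more compounds than are shown below. What is called first, only, known or untested is meant among the compounds shown, and "the series" means these compounds.

For the measured compounds named here, compound 2 `CN(C)CCn1cnnc1-c1cc(Oc2ccc(NC(=O)N/N=C/c3c[nH]c4ccccc34)cc2F)ccn1` is the only compound in this set with a number in hand: in an ADME assay on WI-38 cells (Homo sapiens) for cytotoxicity, read by MTT assay, with a stated time of 72 h (on this read-out higher numbers stand for weaker inhibition and lower numbers for stronger inhibition), compound 2 gives 3620 nM. For compound 1 `CN(C)CCn1cnnc1-c1cc(Oc2ccc(NC(=O)N/N=C/c3ccc(O)c(F)c3)cc2F)ccn1` this assay records "not determined" (no result reported), so no number stands beside it. Compound 3 `COc1ccc(/C=N/NC(=O)Nc2ccc(Oc3ccnc(-c4nncn4CCN(C)C)c3)c(F)c2)c(OC)c1` differs from compound 2 in one place: 2,4-dimethoxyphenyl in place of 1H-indol-3-yl on a carbon with a double bond to nitrogen. Going by the values given here, no pair of measured compounds shows what such a change does here, so the expectation rests on compound 2 alone. A change of this kind is expected to bring little movement, a 1.2-fold higher number from compound 2 to compound 3 (0.09 log units; within the scatter), with no clear direction beyond the usual scatter. Compound 3 is estimated at 4500 nM, within a range from 1500 nM to 13000 nM.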

Compound 3, half-maximal inhibitory concentration: 6630 nM
The estimate for compound 3 lay 1.5-fold (0.17 log units) below the measured number; low and high end bracket the measured number.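

In this assay, placing 2,4-dimethoxyphenyl instead of 1H-indol-3-yl on the carbon with a double bond to nitrogen gives a 1.8-fold higher number from compound 2 to compound 3 (0.26 log units; within the scatter). This single step suggests that the reading at this position does not depend on keeping the hydrogen-bond donor of 1H-indol-3-yl. Nothing shown explains this result. On these data alone, what a carboxylic acid or an amine on this carbon would do in this assay remains open. One step also cannot show whether other aromatic rings here would read the same.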